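From a Carboxyphenyl Arm to an Aminomethyl Arm

The source may report more compounds than this note shows. Statements on the series, on what has been measured and on what is new or still open speak of the compounds shown alone.

Of the compounds shown here, three sharing one core have been measured in an assay on isolated protein (Oryctolagus cuniculus) with Thromboxane-A synthase (Homo sapiens) as the target, tested at 1 uM; a higher number here means more inhibition at the concentration tested (going by the name of the read-out), a lower number less inhibition. Compound 1 `CCn1nc(-c2cccnc2)c2ccccc2c1=O` gives 87% in this assay. Compound 2 `O=c1c2ccccc2c(-c2cccnc2)nn1C1CCCC1`, which differs by a cyclopentyl in place of ethyl on an aromatic nitrogen, gives 97%; the step of a number 10 percentage points higher from compound 1 to compound 2 (within the scatter) stays within the scatter. Compound 3 `O=C(O)c1ccc(Cn2nc(-c3cccnc3)c3ccccc3c2=O)cc1` gives 64%, the lowest of the three numbers: compound 1 stands higher by a step beyond the scatter, and compound 2 further still, as the step of a number 23 percentage points lower from compound 1 to compound 3 (beyond the scatter) shows.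

Compound 4 `NCCn1nc(-c2cccnc2)c2ccccc2c1=O` has not yet been measured in this assay. It differs from compound 3 as follows: aminomethyl in place of 4-carboxyphenyl on a saturated chain carbon bound to an aromatic nitrogen. For the measured compounds named here, the only measured step that bears directly on this place is the one from compound 1 to compound 3, where the arrival of the 4-carboxyphenyl cost a modest amount beyond the scatter. Going by the values given here, its departure is therefore expected to recover much of that loss, while the aminomethyl that enters is small and has no measured precedent here, so the account stays cautious. Compound 4 is expected to give 80% in this assay, within a range from 65% to 92%. The expected step of a number 16 percentage points higher from compound 3 to compound 4 (beyond the scatter) would be an upward one, of roughly the size seen between compound 1 and compound 3 but in reverse.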

Compound 4, a percentage reported as inhibition, at one concentration (the size of the read-out at that concentration, not a potency): 29%
Compound 4: the middle estimate sits 51 percentage points above what was measured; measured number below the stated range.
By their numbers in this assay, from the lowest: compound 4; then compound 3; then compounds 1 and 2 (each within the scatter of the next).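

In this assay, for the compounds shown here, this place proves far more sensitive than the earlier compounds showed: amino in place of hydrogen on a saturated chain carbon, two bonds along the chain from an aromatic nitrogen, gives a step of a number 58 percentage points lower from compound 1 to compound 4 (beyond the scatter), which is large, whereas the step of a number 23 percentage points lower from compound 1 to compound 3 (beyond the scatter) was only modest. The size of the entering group does not set the number on its own, as the aminomethyl, much the smaller group, gives a number 35 percentage points lower from compound 3 to compound 4 (beyond the scatter), and the 2-aminoethyl in place of cyclopentyl on the aromatic nitrogen gives a number 68 percentage points lower from compound 2 to compound 4 (beyond the scatter). Nothing measured here accounts for this large loss.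

The compounds shown leave open whether the loss follows the amine itself or its place on the chain, a question that a longer chain such as 3-aminopropyl would help to settle. They also leave open whether a hydroxyl or an acetamide on the same saturated chain carbon would give a number near that of compound 4 or near that of compound 1.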